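Working notes: from compound 1 to compound 3

This account rests on a few compounds, and the source may have more. Where it says the series, first, only, none or still open, it means among the compounds named here.

- compound 1 `CCC/N=C1\S/C(=C\c2ccc(O)cn2)C(=O)N1c1ccccc1C`: 2.8 mL.min-1.g-1
- compound 2 `CCC/N=C1\S/C(=C\c2ccc(O)c(C(F)(F)F)c2)C(=O)N1c1ccccc1C`: 1 mL.min-1.g-1

In an ADME assay on microsomes from liver (Homo sapiens) for metabolic stability, read by HPLC, with a stated time of 30 min, tested at 0.5 uM (a lower number here means slower removal, a higher number faster removal of the compound), compound 1 stands highest of the two, and compound 2 lies lower, beyond the scatter. Compound 3 `CCC/N=C1\S/C(=C\c2ccc(O)c(C)c2)C(=O)N1c1ccccc1C` differs from compound 1 as follows: 4-hydroxy-3-methylphenyl in place of 5-hydroxypyridin-2-yl on a double-bonded chain carbon bound to a double-bonded ring carbon. Among the compounds with values here, no measured pair isolates this change, so the expectation is a loose one. A step no larger than the scatter is expected, with no clear direction. The expected 1.1-fold lower number from compound 1 to compound 3 (0.05 log units; within the scatter) stays small. For compound 3 the estimated value is 2.5 mL.min-1.g-1, with an expected range of 1 mL.min-1.g-1 to 6 mL.min-1.g-1.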

Compound 3, intrinsic clearance in microsomes: 2.8 mL.min-1.g-1
Compound 3: middle estimate off by 1.1-fold (0.05 log units), on the low side; measured number inside the range.
By their numbers in this assay, from the lowest: compound 2; then compounds 1 and 3 (each within the scatter of the next).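

In this assay, 4-hydroxy-3-methylphenyl in place of 5-hydroxypyridin-2-yl gives no change at the digits printed from compound 1 to compound 3 (within the scatter), so this exchange on the double-bonded chain carbon leaves the read-out unmoved. Methyl in place of trifluoromethyl on an aromatic carbon gives a 2.8-fold higher number from compound 2 to compound 3 (0.45 log units; beyond the scatter), the first one-place reading at this carbon, with the lower number on the trifluoromethyl side. Compound 2 and compound 3 together thus show that the group on this aromatic carbon can move the number. As far as these compounds go, whether chloro, methoxy or an amine on that aromatic carbon would read like methyl or like trifluoromethyl stays open. No measurement at hand explains either step.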